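The source may report more compounds than this note shows. Statements on the series, on what has been measured and on what is new or still open speak of the compounds shown alone.

Of the compounds shown here, three sharing one core have been tested in a functional assay on K562 cells (Homo sapiens) for cytotoxicity, read by trypan blue exclusion, with a stated time of 96 h (a lower number here means a stronger inhibitor, a higher number a weaker inhibitor), and they differ only in the group on a nitrogen on an aromatic ring. Compound 1 (`COC(=O)C(F)(F)Nc1cc(CS(=O)(=O)/C=C/c2c(OC)cc(OC)cc2OC)ccc1OC`), with difluoro(methoxycarbonyl)methyl there, gives 250 nM. Compound 2 (`COC(=O)C(C)(C)Nc1cc(CS(=O)(=O)/C=C/c2c(OC)cc(OC)cc2OC)ccc1OC`), with 1-(methoxycarbonyl)-1-methylethyl, gives 800 nM. Compound 3 (`COc1cc(OC)c(/C=C/S(=O)(=O)Cc2ccc(OC)c(NCCC(=O)O)c2)c(OC)c1`), with 2-carboxyethyl, gives 5000 nM, the highest number of the three and so the weakest inhibitor in this set.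

Compound 4 (`COc1ccc(C(Nc2cc(CS(=O)(=O)/C=C/c3c(OC)cc(OC)cc3OC)ccc2OC)C(=O)O)cc1`) has carboxy(4-methoxyphenyl)methyl in place of 2-carboxyethyl on a nitrogen on an aromatic ring. Going by the values given here, two measured steps bear on this change, as both alter the same group: a 20-fold higher number from compound 1 to compound 3 (1.30 log units; beyond the scatter), and a 6.3-fold higher number from compound 2 to compound 3 (0.80 log units; beyond the scatter). They show that this group can move the number well beyond the scatter. They are only a partial guide, though. Among the compounds with values here, compound 1 and compound 2 carry a methoxycarbonyl group rather than a carboxy group, and no measured compound has the 4-methoxyphenyl group. Since compound 3 sits at the top of the measured numbers, a modest move downward seems the likelier outcome, with real uncertainty. The step expected in this assay is a 3.3-fold lower number from compound 3 to compound 4 (0.52 log units; beyond the scatter). The estimate for compound 4 is 1500 nM, with an expected range from 250 nM to 8000 nM.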

Compound 4, half-maximal inhibitory concentration: 15 nM
Beside the measured number, compound 4's estimate is 100-fold (2.00 log units) above it; measured number outside the range, below it.
By their numbers in this assay, from the lowest: compound 4; then compound 1; then compound 2; then compound 3.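

In this assay the group on the nitrogen proves able to carry the number much lower than the first three compounds showed: replacing 2-carboxyethyl with carboxy(4-methoxyphenyl)methyl gives a 330-fold lower number from compound 3 to compound 4 (2.52 log units; beyond the scatter) and places compound 4 lowest of the four. The comparison with the two ester-bearing compounds is just as telling, with a 53-fold lower number from compound 2 to compound 4 (1.73 log units; beyond the scatter) and a 17-fold lower number from compound 1 to compound 4 (1.22 log units; beyond the scatter) in this set, so a carboxy group does not by itself keep the number high, as compound 3 taken alone might have suggested. No measurement available here accounts for the size of this gain.

The change brings in a six-membered aromatic ring and its methoxy group while also reshaping the chain that holds the carboxy group, and the compounds shown cannot separate these contributions. From the compounds shown here alone, it remains open whether an unsubstituted phenyl ring, a methoxycarbonyl in place of the carboxy on this same group, or an amine or amide in its place would keep the number this low.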